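Bromo substitution on the rhodanine-type core of compound 1

The source may hold more compounds than are shown below. What is called first, only, known or untested is meant among the compounds shown, and "the series" means these compounds.

Compound 1 `O=C1NC(=S)S/C1=C\C1=Cc2ccccc2OC1` is the parent of this small set. In a functional assay on K562 cells (Homo sapiens) for antiproliferative activity, read by MTT assay, with a stated time of 72 h (on this read-out lower numbers stand for stronger inhibition and higher numbers for weaker inhibition), compound 1 gives 55300 nM. Compound 3 `O=C1NC(=O)/C(=C/C2=Cc3cc(Br)ccc3OC2)S1`, which carries both a bromo group and an oxo group in place of the thioxo group, gives 49800 nM in this assay; the two values lie within the usual scatter of each other. Compound 2 `O=C(O)CN1C(=O)/C(=C/C2=Cc3ccccc3OC2)SC1=S` gives only a limit of the assay, > 100000 nM. Within the data shown here, the one single-place step measured, an at least 1.8-fold higher number from compound 1 to compound 2 (0.25 log units; that floor lies within the scatter), concerns the ring nitrogen and reaches the limit (the limit of > 100000 nM in this assay, at which 1 of the 3 values shown sits), so it says nothing about substitution on the aromatic ring.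

Compound 4 `O=C1NC(=S)S/C1=C\C1=Cc2cc(Br)ccc2OC1` differs from compound 1 by bromo in place of hydrogen on an aromatic carbon. Among the measured compounds shown here, no measured step covers this change alone; compound 3 combines it with a second change and still sits within the scatter of compound 1, which gives no sign of a shift in either direction. The expectation for compound 4 in this assay is therefore a number that does not move beyond the scatter, with the step from compound 1 to compound 4 estimated as a 1.1-fold lower number from compound 1 to compound 4 (0.04 log units; within the scatter). Compound 4 is estimated at 50000 nM, within a range from 20000 nM to 120000 nM.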

Compound 4, half-maximal inhibitory concentration: 33700 nM
For compound 4 the middle estimate is 1.5-fold (0.17 log units) above the measured one; the range from low to high includes it.
By their numbers in this assay, from the lowest: compounds 4, 3 and 1 (each within the scatter of the next). At a limit, above all of these: compound 2.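

Taken alone, bromo in place of hydrogen on an aromatic carbon of the six-membered aromatic ring of carbon only gives a 1.6-fold lower number from compound 1 to compound 4 (0.22 log units; within the scatter) in this assay, the first reading of this position free of a second change and clear of the assay limit. The step shows no shift beyond the scatter for this change at this position, on the core of compound 1. It also yields a new pair differing in one place, the oxo and thioxo groups: compound 3 gives 49800 nM and compound 4 gives 33700 nM, and these values lie within the scatter of each other, so the bromo compounds show no order on that change. No measurement shown accounts for the step from compound 1 to compound 4.

From the compounds shown here alone, whether another group on this aromatic carbon, such as an amine, a methoxy group or a carboxylic acid, would move the number beyond the scatter remains open, as does bromo on another carbon of the ring. Going by these compounds, for compound 2 the value > 100000 nM is a limit and not a number, so the effect of bromo alongside the carboxymethyl group also remains open.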